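The source may report more compounds than this note shows. Statements on the series, on what has been measured and on what is new or still open speak of the compounds shown alone.

Of the compounds shown here, three built on one shared core have been measured in a functional assay on HeLa cells (Homo sapiens) for cytotoxicity, read by MTT assay, with a stated time of 72 h; a higher number here means a weaker inhibitor, a lower number a stronger inhibitor. Compound 1 `COc1ccc(C(=O)c2cc(OC)c(OC)c(OC)c2)cc1NC(=O)/C=C/c1cc(OC)c(OC)c(OC)c1` gives 1500 nM. Compound 2 `COc1ccc(/C=C/C(=O)Nc2cc(C(=O)c3cc(OC)c(OC)c(OC)c3)ccc2OC)cc1` gives 10700 nM. Compound 3 `COc1ccc(C(=O)c2cc(OC)c(OC)c(OC)c2)cc1NC(=O)/C=C/c1ccc(C(F)(F)F)cc1` gives 90 nM, the lowest of the three numbers. Both a 17-fold lower number from compound 1 to compound 3 (1.22 log units; beyond the scatter) and a 120-fold lower number from compound 2 to compound 3 (2.08 log units; beyond the scatter) lie beyond the scatter. Compound 4 `COc1ccc(C(=O)c2cc(OC)c(OC)c(OC)c2)cc1NC(=O)/C=C/c1ccc([N+](=O)[O-])cc1` is not yet measured. It differs from compound 3 in a single place: nitro in place of trifluoromethyl on an aromatic carbon. The step that bears most directly on this change is a 120-fold lower number from compound 2 to compound 3 (2.08 log units; beyond the scatter), since it exchanged the group on that same aromatic carbon and was large; a 17-fold lower number from compound 1 to compound 3 (1.22 log units; beyond the scatter) also involved arrival of the trifluoromethyl group. Among the measured compounds shown here, no measured step shows a nitro group, so how it compares with trifluoromethyl is unknown from these data. Compound 4 is expected to show a step of a 1.7-fold higher number from compound 3 to compound 4 (0.22 log units; within the scatter), which stays within the scatter. Compound 4 is therefore estimated at 150 nM, with a range from 40 nM to 600 nM.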

Compound 4, half-maximal inhibitory concentration: 8500 nM
For compound 4 the middle estimate is 57-fold (1.75 log units) below the measured one; measured number outside the range, above it.
By their numbers in this assay, from the lowest: compound 3; then compound 1; then compounds 4 and 2 (each within the scatter of the next).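

At this aromatic carbon the group matters sharply, and the exchange of trifluoromethyl for nitro is not a neutral swap: a 94-fold higher number from compound 3 to compound 4 (1.98 log units; beyond the scatter). The low number of compound 3 therefore belongs to trifluoromethyl in particular, not to any replacement of methoxy, since nitro cannot be told apart from methoxy here (a 1.3-fold lower number from compound 2 to compound 4 (0.10 log units; within the scatter)) and the 4-nitrophenyl group does not even match the 3,4,5-trimethoxyphenyl group (a 5.7-fold higher number from compound 1 to compound 4 (0.75 log units; beyond the scatter)). Nothing in the data shown gives a reason for this gap between trifluoromethyl and nitro.

Among the compounds shown here, with only three groups compared at this carbon, it remains open how a nitrile, a chlorine atom, an amine or a carboxylic acid would compare. Also open, going by these compounds, is whether trifluoromethyl would keep its low number on another carbon of the same ring.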